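Ring nitrogen changes on the alkyne-borne aryl group

This account rests on a few compounds, and the source may have more. Where it says the series, first, only, none or still open, it means among the compounds named here.

Measured so far:
compound 1 `C#Cc1cccc(C#Cc2ccc3ncn(-c4ccnc(N)n4)c3c2)n1`: 3160 nM
compound 2 `C#Cc1cncc(C#Cc2ccc3ncn(-c4ccnc(N)n4)c3c2)c1`: 63100 nM
compound 3 `C#Cc1ccnc(C#Cc2ccc3ncn(-c4ccnc(N)n4)c3c2)c1`: 316 nM

In an assay on Sf9 cells for inhibition of mitogen-activated protein kinase kinase kinase 14 variant S549D (Homo sapiens), with a stated time of 30 min, in the presence of a further agent that is not named here (on this read-out lower numbers stand for stronger inhibition and higher numbers for weaker inhibition), compound 3 gives 316 nM, the lowest number of the three. The nearest of the others is compound 1, with a 10-fold lower number from compound 1 to compound 3 (1.00 log units; beyond the scatter); the furthest is compound 2, with a 200-fold lower number from compound 2 to compound 3 (2.30 log units; beyond the scatter). The third step, a 20-fold higher number from compound 1 to compound 2 (1.30 log units; beyond the scatter), shows that moving the single ring nitrogen within the aryl group on the triple-bonded carbon shifts this assay strongly in both directions. Every change measured in the series is at this one place, and each lies beyond the scatter.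

Compound 4 `C#Cc1cc(C#Cc2ccc3ncn(-c4ccnc(N)n4)c3c2)ncn1` is the next member. The change is a group of 8 heavy atoms (6 carbon, 2 nitrogen; one six-membered aromatic ring with 2 hetero atoms) in place of a group of 8 heavy atoms (7 carbon, 1 nitrogen; one six-membered aromatic ring with 1 hetero atom), on a triple-bonded carbon. The group that leaves, 4-ethynylpyridin-2-yl, is the one that gave the lowest number; the group that enters keeps its nitrogen pattern and carries a second ring nitrogen. Among the measured compounds shown here, no measured pair adds a nitrogen in this way, so the three steps give only the scale of what ring-nitrogen changes here can do, not the direction. Since the measured steps ranged from modest to large, the expected step is a 2.5-fold higher number from compound 3 to compound 4 (0.40 log units; beyond the scatter), a moderate rise in the number from compound 3 to compound 4. For compound 4 the estimate in this assay is 800 nM, with a range of 150 nM to 4000 nM.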

Compound 4, half-maximal inhibitory concentration: 50100 nM
Compound 4: middle estimate off by 63-fold (1.80 log units), on the low side, and the stated range ends below it.
By their numbers in this assay, from the lowest: compound 3; then compound 1; then compounds 4 and 2 (each within the scatter of the next).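

In this assay, among the compounds shown here, the group with two ring nitrogens supplies the direction that the earlier compounds could not give: a 160-fold higher number from compound 3 to compound 4 (2.20 log units; beyond the scatter), so retaining the nitrogen pattern of 4-ethynylpyridin-2-yl does not retain its low number once a second ring nitrogen is present. The same group also stands poorly against the other pyridine isomer, with a 16-fold higher number from compound 1 to compound 4 (1.20 log units; beyond the scatter), whereas a 1.3-fold lower number from compound 2 to compound 4 (0.10 log units; within the scatter) leaves those two compounds indistinguishable. Ring-nitrogen count alone therefore does not set the number at this place, since a one-nitrogen ring and a two-nitrogen ring give matching results in that last pair, while the one-nitrogen rings of the first three compounds span the full range of the series. No available data offer an explanation for these steps.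

The compounds shown leave open what a phenyl ring with no ring nitrogen would give on the triple-bonded carbon, and whether the low number of compound 3 survives if its ethynyl group gives way to a nitrile or an amine. They also leave open whether the ordering of these aryl groups would hold on any core other than the one shared here.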